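Trimming a dimethoxy group on a sulfonamide chain

The source may report more compounds than this note shows. Statements on the series, on what has been measured and on what is new or still open speak of the compounds shown alone.

The compounds here share a bis(trifluoromethyl)phenyl sulfonamide joined through a short chain to an amine that carries a benzyl group, and they were tested in a functional assay on Capan-2 cells (Homo sapiens) for inhibition, read by MTT assay, with a stated time of 72 h; a lower number here means a stronger inhibitor of growth, a higher number a weaker inhibitor of growth. Compound 2 `COc1ccc(CNCCCNS(=O)(=O)c2cc(C(F)(F)F)cc(C(F)(F)F)c2)cc1OC` gives 15000 nM, the highest number among the three measured compounds. Its nearest neighbour is compound 3 `O=S(=O)(NCCCNCc1ccc(Cl)c(C(F)(F)F)c1)c1cc(C(F)(F)F)cc(C(F)(F)F)c1`, which gives 9100 nM, and the furthest is compound 1 `O=S(=O)(NCCCCNCc1ccc(Br)cc1)c1cc(C(F)(F)F)cc(C(F)(F)F)c1`, which gives 1900 nM. Compound 1 differs from compound 2 in both the chain and the aryl group, so its value only shows where the series can reach. The step from compound 2 to compound 4 `COc1ccccc1CNCCCNS(=O)(=O)c1cc(C(F)(F)F)cc(C(F)(F)F)c1` is 2-methoxyphenyl in place of 3,4-dimethoxyphenyl on a saturated chain carbon bound to an amine nitrogen. For the measured compounds named here, the only measured step of the same kind is a 1.6-fold lower number from compound 2 to compound 3 (0.22 log units; within the scatter), a change of the same aryl group that stayed within the scatter. On that basis the step is expected to be small, a 1.5-fold lower number from compound 2 to compound 4 (0.18 log units; within the scatter), in this assay. Compound 4 is therefore estimated at 10000 nM, with a likely range from 3000 nM to 30000 nM.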

Compound 4, concentration for 50% growth inhibition: 6000 nM
Compound 4: middle estimate off by 1.7-fold (0.22 log units), on the high side, within the range that was stated.
By their numbers in this assay, from the lowest: compound 1; then compounds 4, 3 and 2 (each within the scatter of the next, the first and the last beyond it).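

In this assay the aryl group on a saturated chain carbon bound to an amine nitrogen can move the number beyond the scatter, as shown by a modest step, a 2.5-fold lower number from compound 2 to compound 4 (0.40 log units; beyond the scatter), when 2-methoxyphenyl replaces 3,4-dimethoxyphenyl. The 2-methoxyphenyl and 4-chloro-3-(trifluoromethyl)phenyl groups cannot be told apart here, with a 1.5-fold lower number from compound 3 to compound 4 (0.18 log units; within the scatter) lying within the scatter, so quite different aryl groups can give similar numbers. The modest step, a 3.2-fold higher number from compound 1 to compound 4 (0.50 log units; beyond the scatter), cannot be read as one change, since the chain and the aryl group both differ.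

Nothing available explains why the 2-methoxyphenyl compound differs from the 3,4-dimethoxyphenyl compound. The compounds shown leave open whether this step comes from losing one methoxy group or from where the remaining one sits, a question that an unsubstituted phenyl or a 4-methoxyphenyl on the same chain could help to answer.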